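Swapping fluoro for chloro close to the assay limit

The compounds below may be only part of what the source reports. "The series", "measured", "known", "first", "only" and "open" are said of these compounds alone.

In a functional assay on PANC-1 cells (Homo sapiens) for cytotoxicity, read by WST assay, with a stated time of 24 h (a higher number here means a weaker inhibitor, a lower number a stronger inhibitor), compound 2 (`COc1ccc(CCCCCCCCC(=O)N2CCCCC2)cc1`) gives 89300 nM and compound 3 (`O=C(CCCCCCCCc1ccc(F)cc1)N1CCCCC1`) gives 99800 nM, two numbers that lie within the scatter of each other. Compound 1 (`O=C(CCCCCCCCCCc1ccccc1)N1CCCCC1`) gives > 100000 nM, which is a limit of the assay and not a number. Among the compounds with values here, compound 3 therefore stands level with the only other true number in this small set, and both lie close to that limit.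

The next compound, compound 4 (`O=C(CCCCCCCCc1ccc(Cl)cc1)N1CCCCC1`), has chloro in place of fluoro on an aromatic carbon, para to a large group (chloro in place of fluoro on an aromatic carbon). Within the data shown here, no measured step makes this exact swap, so the neighbouring steps have to serve as a guide. Changing the chain end to 4-methoxyphenyl gave an at least 1.1-fold lower number from compound 1 to compound 2 (0.04 log units; that floor lies within the scatter). Changing it to 4-fluorophenyl gave a number no higher from compound 1 to compound 3 (the limit leaves the size open).

On these data alone, the closest guide is a change at the same aromatic carbon, which gave a 1.1-fold higher number from compound 2 to compound 3 (0.05 log units; within the scatter), so no step beyond the scatter is expected in this assay, and the direction stays open. The estimated step is a 1.2-fold lower number from compound 3 to compound 4 (0.07 log units; within the scatter). For compound 4 the estimated value is 85000 nM, with an expected range from 42000 nM to 130000 nM.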

Compound 4, half-maximal inhibitory concentration: 65500 nM
Beside the measured number, compound 4's estimate is 1.3-fold (0.11 log units) above it; measured number inside the range.
By their numbers in this assay, from the lowest: compounds 4, 2 and 3 (each within the scatter of the next). At a limit, above all of these: compound 1.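

In this assay, within the data shown here, chloro in place of fluoro on the aromatic carbon para to a large group gives a 1.5-fold lower number from compound 3 to compound 4 (0.18 log units; within the scatter), the first direct reading of one halogen exchanged for another at this position. Chloro in place of methoxy at the same carbon gives a 1.4-fold lower number from compound 2 to compound 4 (0.13 log units; within the scatter), so fluoro, methoxy and chloro at this position have produced no step beyond the scatter, and this change does not separate the compounds in this assay. The comparison with the chain-end phenethyl compound gives an at least 1.5-fold lower number from compound 1 to compound 4 (0.18 log units; that floor lies within the scatter), and that figure is only a floor, because the value for compound 1 is a limit of the assay and not a number: the limit of > 100000 nM in this assay, at which 1 of the 4 values shown sits.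

The compounds shown leave open whether any group at this aromatic carbon can move the number beyond the scatter, and an amine or a carboxylic acid there would be a much sharper change than exchanging one halogen for another. On these data alone, it also remains open how the number responds to a change away from this ring, such as a shorter chain between the ring and the carbonyl.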